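Dimethylamino in place of fluoro in compound 1

The source may report more compounds than this note shows. Statements on the series, on what has been measured and on what is new or still open speak of the compounds shown alone.

Among the measured compounds shown here, compound 1 (`NS(=O)(=O)c1ccc(/C=C/c2ccc(F)cc2)cc1`) gives 4810 nM in a functional assay on NCI-H522 cells (Homo sapiens) for inhibition (on this read-out higher numbers stand for weaker inhibition of growth and lower numbers for stronger inhibition of growth), and so holds the lower of the two numbers known so far. Compound 2 (`NS(=O)(=O)c1ccc(/C=C/c2cccc(O)c2)cc1`) gives 12200 nM and its gap to compound 1 lies beyond the usual scatter. Compound 3 (`CN(C)c1ccc(/C=C/c2ccc(S(N)(=O)=O)cc2)cc1`) has not yet been measured. It carries dimethylamino in place of fluoro on an aromatic carbon, para to a large group (dimethylamino in place of fluoro on an aromatic carbon). For the measured compounds named here, no measured pair shows a change at this place, so the data give no direct guide to the size of the step. A small step towards a lower number in this assay is expected, one that may not clear the scatter. The estimate amounts to a 1.6-fold lower number from compound 1 to compound 3 (0.21 log units; within the scatter) as an expected step. Compound 3 is expected at 3000 nM with an estimated range from 800 nM to 11000 nM as its likely span.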

Compound 3, concentration for 50% growth inhibition: 6880 nM
For compound 3 the middle estimate is 2.3-fold (0.36 log units) below the measured one, and the stated range covers the measured number.
By their numbers in this assay, from the lowest: compounds 1, 3 and 2 (each within the scatter of the next, the first and the last beyond it).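

In this assay, among the compounds shown here, dimethylamino in place of fluoro on an aromatic carbon, para to a large group, gives a 1.4-fold higher number from compound 1 to compound 3 (0.16 log units; within the scatter) and is the only step read at this position. The position thus accepts dimethylamino, with its 3 heavy atoms against the 1 of fluoro, without a step that clears the scatter, so this read-out does not separate the two groups. Nothing at hand offers an explanation for this result.

The compounds shown leave open whether a different group at this position, such as a carboxylic acid or a methoxy group, would move the number beyond the scatter. They also leave open whether any group here can shift the number in either direction, as one step between two groups gives no trend.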